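Heptyl gives way to 4-hydroxyphenyl

A few compounds are considered here, and "the series" means these few. Any claim that something is new, unique, unknown or untested is made for them only; others in the source may bear on it.

Of the compounds shown here, three on a shared core have been measured in a physicochemical assay for solubility, read by HPLC, at pH 7.4; a lower number here means a less soluble compound, a higher number a more soluble compound. Among the measured compounds shown here, compound 1 (`Cc1[nH]c2ccccc2c(=O)c1Cc1ccccc1`) gives 10000 nM, the only true number so far. Compound 2 (`CCCCCCC/C=C/c1c(C)[nH]c2ccccc2c1=O`) gives < 2000 nM, which is a limit of the assay and not a number. Compound 3 (`C=C(CCCCCCC)c1c(C)[nH]c2ccccc2c1=O`) gives < 2000 nM, which is also a limit. From the compounds shown here alone, compound 2 therefore stands at the limit of < 2000 nM in this assay, at which 2 of the 3 values shown sit, and its true value remains unknown.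

The next compound is compound 4 (`Cc1[nH]c2ccccc2c(=O)c1/C=C/c1ccc(O)cc1`), still unmeasured in this assay. It places 4-hydroxyphenyl in place of heptyl on a double-bonded chain carbon bound to a double-bonded chain carbon.

For the measured compounds named here, no two measured compounds differ in one place, so the size of this step has no direct precedent. The expectation rests on a simple observation: both limits belong to compounds carrying a heptyl chain. Compound 1, which has no such chain, reaches 10000 nM. Compound 4 also lacks that chain. A rise in solubility beyond the usual scatter is therefore expected, although another limit remains possible. The expected step is an at least 3.0-fold higher number from compound 2 to compound 4 (0.47 log units; beyond the scatter). Compound 4 is estimated at 6000 nM, with an expected range from 2000 nM to 20000 nM.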

Compound 4, solubility: > 20000 nM
Compound 4 ended at the assay's limit (the forecaster's own chance of this, stated with the estimate: 20%); middle value at least 3.3-fold (0.52 log units) away from the limit.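

In this assay, among the compounds shown here, placing 4-hydroxyphenyl in place of heptyl on a double-bonded chain carbon bound to a double-bonded chain carbon gives an at least 10-fold higher number from compound 2 to compound 4 (1.00 log units; beyond the scatter), the first change in a single place that can be read on this series, and it shows that this position can carry a change large enough to span the assay's range from one limit to the other. Compound 2 stands at a limit of the assay and not at a number: the limit of < 2000 nM in this assay, at which 2 of the 4 values shown sit. From the compounds shown here alone, compound 4 also stands at a limit and not at a number, so the step has a lower bound only and its full size remains unknown: the limit of > 20000 nM in this assay, at which 1 of the 4 values shown sits.

The entering group differs from heptyl by an aromatic ring, a hydrogen-bond donor and a hydrogen-bond acceptor, with the heavy atom count unchanged, and the compounds shown cannot separate these features, so it stays open whether the plain phenyl group without its hydroxyl would read the same way. They also leave open how a shorter chain, an amine or a carboxylic acid in this place would read in this assay.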